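This account rests on a few compounds, and the source may have more. Where it says the series, first, only, none or still open, it means among the compounds named here.

Compound 1 `Cc1ccc2c(=O)cc(/C=C/[S+](C)[O-])oc2c1`: 7000 nM
Compound 2 `C[S+]([O-])/C=C/c1cc(=O)c2ccccc2o1`: 8000 nM
Compound 3 `Cc1cccc2c(=O)cc(/C=C/[S+](C)[O-])oc12`: 6800 nM

In a functional assay on DLD-1 cells (Homo sapiens) for cytotoxicity, with a stated time of 48 h (on this read-out higher numbers stand for weaker inhibition and lower numbers for stronger inhibition), compound 3 gives 6800 nM, a number that cannot be told apart from those of the other two compounds. The next compound, compound 4 `COc1cccc2c(=O)cc(/C=C/[S+](C)[O-])oc12`, keeps the shared core and differs at a single place, with methoxy in place of methyl on an aromatic carbon.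

Going by the values given here, two measured steps bear on this change, although neither involves methoxy. Hydrogen in place of methyl gave a 1.1-fold higher number from compound 1 to compound 2 (0.06 log units; within the scatter), and methyl in place of hydrogen gave a 1.2-fold lower number from compound 2 to compound 3 (0.07 log units; within the scatter). Both are small and lie within the scatter, so swapping methyl and hydrogen made no visible difference among these three compounds. What methoxy does here has not been measured, so the expectation in this assay is for no step beyond the scatter, in either direction. The expected step is a 1.0-fold higher number from compound 3 to compound 4 (0.01 log units; within the scatter). Compound 4 is estimated at 7000 nM, with an expected range of 3500 nM to 14000 nM.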

Compound 4, half-maximal inhibitory concentration: 9000 nM
For compound 4 the middle estimate is 1.3-fold (0.11 log units) below the measured one; the measured number falls inside the stated range.
By their numbers in this assay, from the lowest: compounds 3, 1, 2 and 4 (each within the scatter of the next).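

In this assay, methoxy is the only group among these compounds that places an oxygen on this aromatic carbon, yet the change from methyl gives a 1.3-fold higher number from compound 3 to compound 4 (0.12 log units; within the scatter) and the change from hydrogen gives a 1.1-fold higher number from compound 2 to compound 4 (0.05 log units; within the scatter). At this carbon, then, hydrogen, methyl and methoxy cannot be told apart in this cell test, even though methoxy carries a hydrogen-bond acceptor that methyl lacks. No supporting measurement is available that could account for this flat result.

The compounds shown leave open whether an amine, a carboxylic acid or a longer chain such as butoxy at this carbon would also stay within the scatter. They also leave open whether methoxy would behave the same way at the other aromatic carbon, where compound 1 carries its methyl.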